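The source may hold more compounds than are shown below. What is called first, only, known or untested is meant among the compounds shown, and "the series" means these compounds.

Among the measured compounds shown here, compound 2 `CCC(C)NC(=O)[C@H]1OC(n2cnc3c(N)ncnc32)[C@H](O)[C@@H]1O` is the weaker binder of the two compounds measured so far. In an assay on cell membranes for binding affinity to 2-oxoglutarate receptor 1 (Rattus norvegicus), read by radioligand binding (on this read-out lower numbers stand for stronger inhibition and higher numbers for weaker inhibition), compound 2 gives 198 nM, the higher of the two numbers. For the measured compounds named here, its only neighbour is compound 1 `CCCCCCCCCNC(=O)[C@H]1OC(n2cnc3c(N)ncnc32)[C@H](O)[C@@H]1O`, which in this assay gives 31 nM. Going by the values given here, the one measured step between them, a 6.4-fold higher number from compound 1 to compound 2 (0.81 log units; beyond the scatter), shows that a shorter chain on the amide-type nitrogen went with a clearly higher number.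

Compound 3 `Nc1ncnc2c1ncn2C1O[C@H](C(=O)NC2CCCCCC2)[C@@H](O)[C@H]1O` has not yet been measured. It differs from compound 2 in one place: cycloheptyl in place of sec-butyl on an amide-type nitrogen. Among the compounds with values here, the entering group is counted as larger than the one it replaces, though not as large as the nonyl chain of compound 1, so the measured step from compound 1 to compound 2 is the only step that bears on this change and it ran in the opposite direction to the change now made.

On that basis compound 3 is expected to give a lower number than compound 2 in this assay, by a step of a 2.8-fold lower number from compound 2 to compound 3 (0.45 log units; beyond the scatter), though smaller than the step between compound 1 and compound 2. The estimate for compound 3 in this assay is 70 nM, with a range from 25 nM to 200 nM.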

Compound 3, inhibition constant: 22 nM
Beside the measured number, compound 3's estimate is 3.2-fold (0.50 log units) above it, and the stated range ends above it.
By their numbers in this assay, from the lowest: compounds 3 and 1 (each within the scatter of the next); then compound 2.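

In this assay the earlier pair left open whether only a long open chain on the amide-type nitrogen went with a low number, and a 9.0-fold lower number from compound 2 to compound 3 (0.95 log units; beyond the scatter) shows that a ring of carbon, cycloheptyl, in place of sec-butyl also does. The two larger groups cannot be told apart at this position, with a 1.4-fold lower number from compound 1 to compound 3 (0.15 log units; within the scatter), so a nonyl chain and a cycloheptyl ring read alike here and, of the three groups shown, only sec-butyl stands clearly apart. No measurement at hand accounts for these differences.

The change from sec-butyl to cycloheptyl adds carbon atoms and a ring in one step, so the compounds shown do not separate the contribution of the ring from that of the added carbon atoms; cyclobutyl, cyclopentyl or a straight heptyl chain on the same nitrogen would bear on that. Going by these compounds, it also remains open how a group carrying a hydroxyl or an amine on the cycloheptyl ring, or a ring larger than cycloheptyl, would read on this nitrogen.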